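Phenyl to 4-chlorophenyl: cytotoxicity notes on the series

The source may report more compounds than this note shows. Statements on the series, on what has been measured and on what is new or still open speak of the compounds shown alone.

Compound 1 `CONC(=S)N/N=C1\C(=O)N(CN2CCN(c3ccccc3)CC2)c2ccc(F)cc21` and compound 3 `CONC(=S)N/N=C1\C(=O)N(CN2CCN(c3ccc(Cl)cc3)CC2)c2ccc(F)cc21` share one core and differ by chloro in place of hydrogen on an aromatic carbon. In an ADME assay on MT4 cells (Homo sapiens) for cytotoxicity, read by spectrophotometry, with a stated time of 5 days (on this read-out lower numbers stand for higher toxicity in this test and higher numbers for lower toxicity in this test), compound 1 gives 227000 nM and compound 3 gives 347000 nM; the step of a 1.5-fold higher number from compound 1 to compound 3 (0.18 log units; within the scatter) is within the scatter, so the two numbers show no difference that can be read.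

Compound 2 `O=C1/C(=N\NC(=S)NO)c2cc(Cl)ccc2N1CN1CCN(c2ccccc2)CC1` has a different core; how its core differs from that of compound 1 is not broken down here. In this assay compound 2 gives 273000 nM, which sits within the scatter of both compound 1 and compound 3.

Compound 4 `O=C1/C(=N\NC(=S)NO)c2cc(Cl)ccc2N1CN1CCN(c2ccc(Cl)cc2)CC1` is not yet measured. It differs from compound 2 by chloro in place of hydrogen on an aromatic carbon, the same change as from compound 1 to compound 3, at the same place. The step from compound 2 to compound 4 in this assay is expected to be a 1.3-fold higher number from compound 2 to compound 4 (0.11 log units; within the scatter), within the scatter, resting on the step of a 1.5-fold higher number from compound 1 to compound 3 (0.18 log units; within the scatter). Compound 4 is thus estimated to give 350000 nM in this assay, with a range from 180000 nM to 700000 nM.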

Compound 4, half-maximal cytotoxic concentration: 268000 nM
Beside the measured number, compound 4's estimate is 1.3-fold (0.12 log units) above it; the measured number falls inside the stated range.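

In this assay, phenyl to 4-chlorophenyl on the second core gives a 1.0-fold lower number from compound 2 to compound 4 (0.01 log units; within the scatter), so again no difference can be read. Set beside the earlier step, the change shows no dependence on the core that can be read: the same change on two cores in this assay, a 1.5-fold higher number (0.18 log units; within the scatter) from compound 1 to compound 3 and a 1.0-fold lower number (0.01 log units; within the scatter) from compound 2 to compound 4, 1.6-fold (0.19 log units) apart, within the scatter of two such steps. This shows that the change has left the cytotoxicity number within the scatter on both cores, and that the two cores give no sign of treating it differently; it does not show that the change has a real effect of a shared size, nor that the same would hold on any further core.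

Open, on these data alone, is whether a different group on this aromatic carbon, such as methoxy, an amine or a carboxylic acid, would give a step beyond the scatter. Also open, as far as these compounds go, is how phenyl to 4-chlorophenyl reads on other cores of the series and in read-outs other than cytotoxicity.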